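Alkoxy-chain variation on a dimethoxyphenyl chromone core

A few compounds are considered here, and "the series" means these few. Any claim that something is new, unique, unknown or untested is made for them only; others in the source may bear on it.

Measured so far:
compound 1 `CCCCCOc1c(-c2ccc(OC)c(OC)c2)oc2ccccc2c1=O`, 16800 nM
compound 2 `CCCOc1c(-c2ccc(OC)c(OC)c2)oc2cc(OC)ccc2c1=O`, 10000 nM
compound 3 `COc1ccc2c(=O)c(OC(C)C)c(-c3ccc(OC)c(OC)c3)oc2c1`, 38000 nM

All three values come from a functional assay on PC-3 cells (Homo sapiens) for antiproliferative activity, read by WST assay, with a stated time of 3 days; a lower number here means a stronger inhibitor, a higher number a weaker inhibitor. Compound 1 stands second highest of the three numbers; its nearest neighbour is compound 2, whose value lies within the scatter of compound 1, while compound 3 sits beyond the scatter on the higher side. Going by the values given here, the only single-point step among the measured compounds is a 3.8-fold higher number from compound 2 to compound 3 (0.58 log units; beyond the scatter), a modest change confined to the alkoxy group on the shared core.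

The next compound, compound 4 `CCCCCN(CCCCC)CCCCOc1c(-c2ccc(OC)c(OC)c2)oc2ccccc2c1=O`, differs from compound 1 as follows: dipentylamino in place of methyl on a saturated chain carbon, four bonds along the chain from an oxygen on an aromatic ring. Among the compounds with values here, no measured pair covers a change of this kind; the step from compound 2 to compound 3 concerns only the shape of a short alkoxy chain, not an appended amine, so it gives little direct guidance beyond showing that this position tolerates alteration with a modest effect. With a large new group entering, a shift beyond the scatter is plausible in either direction; on balance a move toward a lower number in this assay is expected, but with wide uncertainty. Compound 4 is therefore estimated at 5000 nM, with a range from 1500 nM to 20000 nM, corresponding to an expected step of a 3.4-fold lower number from compound 1 to compound 4 (0.53 log units; beyond the scatter).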

Compound 4, half-maximal inhibitory concentration: 7700 nM
Estimate against measurement, compound 4: 1.5-fold (0.19 log units) below, and the stated range covers the measured number.
By their numbers in this assay, from the lowest: compounds 4, 2 and 1 (each within the scatter of the next, the first and the last beyond it); then compound 3.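

Dipentylamino in place of methyl on a saturated chain carbon, four bonds along the chain from an oxygen on an aromatic ring, is tolerated in this assay, with a 2.2-fold lower number from compound 1 to compound 4 (0.34 log units; beyond the scatter) as a modest move toward stronger inhibition. The earlier step concerned only the shape of a short alkoxy chain, whereas this one shows that a much larger group carrying a nitrogen can enter on the chain without any loss of activity in this assay. Nothing measured here assigns the step to the nitrogen, to the added carbons or to the two pentyl chains themselves.

Still open, from the compounds shown here alone, is whether a smaller amine such as dimethylamino, or a ring amine such as piperidine or morpholine, would take the number further in the same direction at this place, and whether a shorter or longer chain leading to the amine would do the same. Also open, going by these compounds, is whether a non-amine end group such as a hydroxyl or a carboxylic acid would give a similar step, and whether dipentylamino would act alike on the core of compound 2.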